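Pyrazole urea series: methoxy to hydroxy on the chlorophenyl ring

This account rests on a few compounds, and the source may have more. Where it says the series, first, only, none or still open, it means among the compounds named here.

Measured compounds:
Compound 1 `COc1cc(-c2nn(-c3cccc(NC(=O)Nc4cc(C(F)(F)F)cc(C(F)(F)F)c4)c3)cc2-c2ccncc2)ccc1Cl` — in a functional assay on OVCAR-3 cells (Homo sapiens) for inhibition, read by sulforhodamine B assay, with a stated time of 48 h (a higher number here means that more compound is tolerated, a lower number that less compound is tolerated), compound 1 gives 3390 nM.
Compound 2 `O=C(Nc1cccc(-n2cc(-c3ccncc3)c(-c3ccc(Cl)c(O)c3)n2)c1)Nc1cc(C(F)(F)F)cc(C(F)(F)F)c1` — in this assay compound 2 gives 3310 nM.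
Compound 3 `COc1cc(-c2nn(-c3cccc(NC(=O)Nc4ccc(Cl)c(C(F)(F)F)c4)c3)cc2-c2ccncc2)ccc1Cl` — in this assay compound 3 gives > 32500 nM, which is a limit of the assay and not a number.

Compound 1 and compound 2 differ in one place only: hydrogen in place of methyl on an oxygen on an aromatic ring. The step in this assay is a 1.0-fold lower number from compound 1 to compound 2 (0.01 log units; within the scatter), so the two values stand together within the usual scatter and no order can be read between them.

Compound 3 carries a different urea aryl group than compound 1; the difference between the two cores is not broken down here. In this assay compound 3 sits at the limit of > 32500 nM in this assay, at which 1 of the 3 values shown sits.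

Compound 4 `O=C(Nc1cccc(-n2cc(-c3ccncc3)c(-c3ccc(Cl)c(O)c3)n2)c1)Nc1ccc(Cl)c(C(F)(F)F)c1` has not yet been measured. It differs from compound 3 by hydrogen in place of methyl on an oxygen on an aromatic ring, the same change that turns compound 1 into compound 2, at the same place. Because the step from compound 1 to compound 2 in this assay was a 1.0-fold lower number from compound 1 to compound 2 (0.01 log units; within the scatter), the expectation is that the same change leaves compound 3 essentially unchanged as well, with an expected step from compound 3 to compound 4 of a step that the limit leaves unreadable from compound 3 to compound 4. Compound 4 is therefore estimated at 40000 nM in this assay, with the expected range running from 15000 nM to 100000 nM, and it is considered likely that the assay again reports only a limit for compound 4 rather than a number.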

Compound 4, concentration lethal to 50% of the cells: > 32500 nM
Compound 4: only a limit was reported; the forecaster's own chance of this, stated with the estimate: 75%; the middle value is on the limit's open side.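

In this assay compound 4 gives > 32500 nM, which is a limit of the assay and not a number. Compound 3 and compound 4 both stand at this limit, so no step can be read between them: the limit of > 32500 nM in this assay, at which 2 of the 4 values shown sit.

As far as these compounds go, whether methoxy to hydroxy alters the read-out when the urea aryl group is that of compound 3 and compound 4 stays open.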